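A few compounds are considered here, and "the series" means these few. Any claim that something is new, unique, unknown or untested is made for them only; others in the source may bear on it.

Going by the values given here, in a functional assay for binding affinity to Norepinephrine transporter (Rattus norvegicus), read by radioligand binding, in the presence of a further agent that is not named here (a higher number here means a weaker inhibitor, a lower number a stronger inhibitor), compound 2 `C1=NCC(Cc2cc3ccccc3o2)N1` gives 63.1 nM, the lower of the two numbers known so far; compound 1 `NC1=NCC(CC2=Cc3ccccc3CC2)O1` gives 1000 nM, a higher number by a margin beyond the usual scatter. Compound 3 `C1=NCC(Cc2cc3cc(-c4ccccc4)ccc3o2)N1` differs from compound 2 in a single place: phenyl in place of hydrogen on an aromatic carbon. Among the compounds with values here, no measured pair shows what adding a phenyl does here, so the direction of the step is open, and a shift that stays within the scatter seems as likely as a modest move either way. Compound 3 is therefore expected to come out near 100 nM, within a range from 25 nM to 400 nM. That estimate corresponds to an expected step of a 1.6-fold higher number from compound 2 to compound 3 (0.20 log units; within the scatter).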

Compound 3, inhibition constant: 158 nM
Compound 3: middle estimate off by 1.6-fold (0.20 log units), on the low side; the measured number falls inside the stated range.
By their numbers in this assay, from the lowest: compound 2; then compound 3; then compound 1.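

In this assay phenyl in place of hydrogen on this aromatic carbon, meta to a fused ring and para to a fused ring, brings a 2.5-fold higher number from compound 2 to compound 3 (0.40 log units; beyond the scatter) and so gives a modestly weaker inhibitor. Going by these compounds alone, this is the first measured step at this position, and it shows that a whole added aromatic ring costs only a modest loss here. Nothing available explains the shift. On these data alone, whether a small methyl, an amine or a carboxylic acid on the same carbon would move the number the same way stays open. So does whether phenyl elsewhere on the shared core would behave alike.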